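Removing trifluoromethyl from a dinitro benzimidazole core

The source may report more compounds than this note shows. Statements on the series, on what has been measured and on what is new or still open speak of the compounds shown alone.

Measured so far in an ADME assay on Vero cells (Chlorocebus sabaeus) for cytotoxicity; a lower number here means that less compound is tolerated, a higher number that more compound is tolerated:
compound 1 `CCC(=O)Nc1ccc(-c2nc3cc(C(F)(F)F)ccc3[nH]2)cc1` — > 100000 nM
compound 2 `O=[N+]([O-])c1ccc(-c2nc3cc(C(F)(F)F)ccc3[nH]2)c([N+](=O)[O-])c1` — 25000 nM
compound 3 `CCC(=O)Nc1ccc(-c2nc3ccccc3[nH]2)cc1` — > 100000 nM

In this assay compound 1 gives > 100000 nM, which is a limit of the assay and not a number. Compound 3 likewise gives > 100000 nM, again a limit. Between them lies the change (hydrogen in place of trifluoromethyl on an aromatic carbon), and because both values are limits the step that the two limits leave unreadable from compound 1 to compound 3 cannot be read in size; the data set shows (the limit of > 100000 nM in this assay, at which 2 of the 3 values shown sit). Among the compounds with values here, compound 2 is the one compound with a number: in this assay compound 2 gives 25000 nM. How the core of compound 2 differs from the core of compound 1 is not broken down here.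

Compound 4 `O=[N+]([O-])c1ccc(-c2nc3ccccc3[nH]2)c([N+](=O)[O-])c1` has not yet been measured. It is related to compound 2 by hydrogen in place of trifluoromethyl on an aromatic carbon, the same change that separates compound 1 from compound 3, and the two place lines are the same word for word. Since the earlier step is not readable, nothing measured says how large this change is on this read-out. The estimate for compound 4 therefore rests on the value of compound 2 25000 nM and on the step of a 1.6-fold higher number from compound 2 to compound 4 (0.20 log units; within the scatter) being expected to stay small. Compound 4 is expected to give about 40000 nM, with a likely range from 15000 nM to 150000 nM.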

Compound 4, half-maximal cytotoxic concentration: > 100000 nM
Compound 4: no number, only a limit; the forecaster's own chance of this, stated with the estimate: 30%; middle value at least 2.5-fold (0.39 log units) away from the limit.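

In this assay, hydrogen in place of trifluoromethyl on an aromatic carbon, carried out on the core of compound 2, gives an at least 4.0-fold higher number from compound 2 to compound 4 (0.60 log units; beyond the scatter). Compound 4 gives > 100000 nM, which is a limit of the assay and not a number, so the step shows a minimum size for this one pair and leaves its full size unknown. The same change on the core of compound 1 cannot be read, so the series offers no second size to set against this one, and nothing here shows that the change has the same size on both cores, since the values on that earlier pair sit at the ceiling that now also holds compound 4: the limit of > 100000 nM in this assay, at which 3 of the 4 values shown sit.

From the compounds shown here alone, it remains open whether a methyl or a single chlorine atom in place of trifluoromethyl on the core of compound 2 would give a number in this assay or would also reach the limit. Also open, going by these compounds, is what an amine in place of either nitro group would do on that core, with trifluoromethyl kept and with it removed.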